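Working notes on cytotoxicity limits, compounds 1 to 4

The source may report more compounds than this note shows. Statements on the series, on what has been measured and on what is new or still open speak of the compounds shown alone.

Measured so far:
compound 1 `CCOC(=O)c1cc(-c2cccc(OCc3ccccc3Cl)c2)on1`: in an ADME assay on Vero cells (Chlorocebus sabaeus) for cytotoxicity, with a stated time of 72 h (a higher number here means a weaker inhibitor, a lower number a stronger inhibitor), compound 1 gives > 128000 nM, a limit of the assay.
compound 2 `CCOC(=O)c1cc(-c2cccc(OCc3ccccc3[N+](=O)[O-])c2)on1`: in this assay compound 2 gives > 128000 nM, a limit of the assay.
compound 3 `CCOC(=O)c1cc(-c2cccc(OCc3ccc(F)c(F)c3)c2)on1`: in this assay compound 3 gives > 128000 nM, a limit of the assay.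

Compound 3 stands at the limit of this assay, and the same holds for the other two compounds, as the limit of > 128000 nM in this assay, at which 3 of the 3 values shown sit, records. No order among compounds 1, 2 and 3 can be read from values that all sit at one limit.

Compound 4 `CCOC(=O)c1cc(-c2cccc(OCc3ccc(F)cc3F)c2)on1` is not yet measured. It differs from compound 3 by 2,4-difluorophenyl in place of 3,4-difluorophenyl on a saturated chain carbon bound to an oxygen on an aromatic ring. The measured steps that touch the same place are a step that the two limits leave unreadable from compound 1 to compound 3 and a step that the two limits leave unreadable from compound 2 to compound 3; the remaining step, a step that the two limits leave unreadable from compound 1 to compound 2, is likewise unreadable. None of these steps gives a size or a direction. Nothing in the measured compounds points to a step beyond the scatter in this assay, and the expectation is that compound 4 also sits at the limit.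

Compound 4 is expected at 200000 nM, with a range from 100000 nM to 500000 nM. For compound 4 the estimated step is a step that the limit leaves unreadable from compound 3 to compound 4, within the scatter.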

Compound 4, half-maximal inhibitory concentration: > 128000 nM
Compound 4 ended at the assay's limit (the forecaster's own chance of this, stated with the estimate: 85%); the middle value lies beyond the limit too.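

No step can be read between compound 4 and compounds 1, 2 and 3 in this assay, as all four compounds sit at one limit: the limit of > 128000 nM in this assay, at which 4 of the 4 values shown sit.

The compounds shown leave open how far beyond that limit each compound lies, and whether any of them differ in cytotoxicity.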